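Chloro-to-Hydroxy Exchange Across Two Related Cores

The source may hold more compounds than are shown below. What is called first, only, known or untested is meant among the compounds shown, and "the series" means these compounds.

Measured in a functional assay on MCF7 cells (Homo sapiens) for inhibition, read by MTT assay, with a stated time of 72 h; on this read-out higher numbers stand for weaker inhibition and lower numbers for stronger inhibition:
Compound 1 `COc1cc(OC)c(-c2cc(=O)c3cc(Cl)ccc3o2)cc1OC`: > 150000 nM
Compound 2 `COc1cc(OC)c(OC)cc1/C=C/C(=O)c1cc(Cl)ccc1O`: > 150000 nM
Compound 3 `COc1cc(OC)c(OC)cc1/C=C/C(=O)c1cc(O)ccc1O`: > 150000 nM

The value of compound 1 is a limit of the assay, not a number. The value of compound 2 is likewise a limit. The value of compound 3 is a limit as well.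

Compound 2 and compound 3 share one core and differ by hydroxy in place of chloro on an aromatic carbon. The step that the two limits leave unreadable from compound 2 to compound 3 cannot be read, because of the limit of > 150000 nM in this assay, at which 3 of the 3 values shown sit. Compound 1 rests on a different core; how the two cores differ is not broken down here.

Compound 4 `COc1cc(OC)c(-c2cc(=O)c3cc(O)ccc3o2)cc1OC` is not yet measured. It differs from compound 1 by hydroxy in place of chloro on an aromatic carbon. Going by the values given here, this is the same kind of change as the one from compound 2 to compound 3, though the surroundings differ: in compound 4 the carbon belongs to a fused or bridged system of two rings and is meta to a fused ring and para to a fused ring, whereas in compound 3 it is meta to a large group and para to a hydroxy group.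

For compound 4 a step that the limit leaves unreadable from compound 1 to compound 4 is expected, resting on compound 1 sitting at the limit > 150000 nM and on the unreadable step that the two limits leave unreadable from compound 2 to compound 3. Compound 4 is estimated at 200000 nM, between 60000 nM and 600000 nM, and is expected most likely to return only a limit again.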

Compound 4, half-maximal inhibitory concentration: > 150000 nM
Compound 4: no number, only a limit; the forecaster's own chance of this, stated with the estimate: 85%; the middle value does not contradict the limit.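

Compound 4 gives > 150000 nM, which is a limit of the assay and not a number. The step from compound 1 to compound 4 therefore cannot be read, any more than the one from compound 2 to compound 3, because every compound rests at the same limit: the limit of > 150000 nM in this assay, at which 4 of the 4 values shown sit.

The compounds shown leave open whether hydroxy in place of chloro changes inhibition on either core.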